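Compound 4: phenyl in place of naphthalen-1-yl

A few compounds are considered here, and "the series" means these few. Any claim that something is new, unique, unknown or untested is made for them only; others in the source may bear on it.

In an ADME assay on HEK-293T cells (Homo sapiens) for inhibition, read by CCK-8 assay, with a stated time of 48 h, tested at 20 uM (on this read-out higher numbers stand for more inhibition of growth at the one concentration tested and lower numbers for less inhibition of growth), compound 1 `Cc1ccc(S(=O)(=O)Oc2ccccc2/C=C(\C#N)C(=O)Nc2nnc(C)s2)cc1` gives 35%, compound 2 `COc1ccc(Cc2nnc(NC(=O)/C(C#N)=C/c3ccccc3OS(=O)(=O)c3ccc(C)cc3)s2)cc1` gives 21% and compound 3 `Cc1ccc(S(=O)(=O)Oc2ccccc2/C=C(\C#N)C(=O)Nc2nnc(Cc3cccc4ccccc34)s2)cc1` gives 23%. Compound 3 therefore stands close to one neighbour and apart from the other: the smallest gap is a number 2 percentage points higher from compound 2 to compound 3 (within the scatter), the widest a number 12 percentage points lower from compound 1 to compound 3 (beyond the scatter).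

Compound 4 `Cc1ccc(S(=O)(=O)Oc2ccccc2/C=C(\C#N)C(=O)Nc2nnc(Cc3ccccc3)s2)cc1` keeps the rest of compound 3 and carries phenyl in place of naphthalen-1-yl on a saturated chain carbon bound to an aromatic carbon. The same difference, cut one bond further out, reads (naphthalen-1-yl)methyl to benzyl.

Among the measured compounds shown here, the closest precedent is the only measured exchange of one aromatic group for another at this place, a number 2 percentage points higher from compound 2 to compound 3 (within the scatter). The two steps that put an aromatic group on this carbon in the first place, a number 14 percentage points lower from compound 1 to compound 2 (beyond the scatter) and a number 12 percentage points lower from compound 1 to compound 3 (beyond the scatter), were modest and ran the same way. Compound 4 also keeps an aromatic group there, so it is expected to stay with compound 2 and compound 3 rather than move towards compound 1. For the measured compounds named here, no measured compound carries plain phenyl, so the range stays wide.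

In this assay no change beyond the scatter is expected, the estimated step being a number 1 percentage points higher from compound 3 to compound 4 (within the scatter). For compound 4 the estimated value is 24%, with an expected range from 14% to 35%.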

Compound 4, percent growth inhibition at one concentration: 15%
Beside the measured number, compound 4's estimate is 9 percentage points above it; the range from low to high includes it.
By their numbers in this assay, from the lowest: compounds 4, 2 and 3 (each within the scatter of the next); then compound 1.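

In this assay the exchange of naphthalen-1-yl for phenyl on a saturated chain carbon bound to an aromatic carbon gives a number 8 percentage points lower from compound 3 to compound 4 (within the scatter) and the exchange of methoxy for hydrogen on an aromatic carbon gives a number 6 percentage points lower from compound 2 to compound 4 (within the scatter) as its reading, so this position has now taken three aromatic groups that cannot be told apart, whether the group has one ring or two. Loss of the second ring also brings no return towards compound 1, since a number 20 percentage points lower from compound 1 to compound 4 (beyond the scatter) remains a modest step, and all three compounds with an aromatic group on this carbon share the same direction from compound 1, with none of them going against it. Nothing measured on these compounds bears on what lies behind these numbers.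

Going by these compounds, whether the step from compound 1 needs an aromatic group at all stays open, as a cyclohexyl ring or a longer chain such as n-butyl on this carbon could sit with either side of the series. Also open, on these data alone, is how an amine or a carboxylic acid on the phenyl ring of compound 4 would read in this assay and whether any group here would move the number beyond the scatter from compound 4.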